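The source may hold more compounds than are shown below. What is called first, only, known or untested is meant among the compounds shown, and "the series" means these compounds.

Compound 3 `COC(=O)CCNC(=O)[C@@H]1O[P@@](=O)(OCOC(=O)c2scnc2C)OCC1(C)C` shares its core with compound 1 `COC(=O)CCNC(=O)[C@@H]1O[P@@](=O)(OCOC(=O)c2ccns2)OCC1(C)C` and compound 2 `COC(=O)CCNC(=O)[C@@H]1O[P@@](=O)(OCOC(=O)c2ccnn2C)OCC1(C)C`, the three differing only in the aromatic ring attached to a carbonyl carbon. In an ADME assay on blood (Homo sapiens) for pharmacokinetics (on this read-out lower numbers stand for a shorter-lived compound and higher numbers for a longer-lived compound), compound 1 reports only a limit, < 0.16 h. Compound 2 likewise reports only a limit, > 1 h. Compound 3 also gives only a limit, > 1 h, so it stands among the longer-lived entries without a fixed number (the limit of > 1 h in this assay, at which 2 of the 3 values shown sit). The measured steps show an at least 6.2-fold higher number from compound 1 to compound 2 (0.79 log units; beyond the scatter) and an at least 6.2-fold higher number from compound 1 to compound 3 (0.79 log units; beyond the scatter), while a step that the two limits leave unreadable from compound 2 to compound 3 cannot be sized from two limits. Compound 4 `COC(=O)CCNC(=O)[C@@H]1O[P@@](=O)(OCOC(=O)c2cc(C(C)(C)C)n[nH]2)OCC1(C)C` arises from compound 3 through (3-(tert-butyl)-1H-pyrazol-5-yl in place of 4-methyl-1,3-thiazol-5-yl on a carbonyl carbon). Among the measured compounds shown here, no measured step exchanges a ring carrying a hydrogen-bond donor, so none bears directly on this change; the two readable steps show only that both rings other than 1,2-thiazol-5-yl kept the compound beyond the upper limit. Compound 4 is therefore expected to remain in that longer-lived region, with a step that the limit leaves unreadable from compound 3 to compound 4 expected as no step beyond the scatter. Compound 4 is estimated at 1.5 h, between 0.4 h and 5 h.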

Compound 4, half-life: > 1 h
Compound 4 was reported as a limit; the forecaster's own chance of this, stated with the estimate: 60%; the middle value lies beyond the limit too.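

In this assay compound 4 gives > 1 h as a limit, not a number. Placing 3-(tert-butyl)-1H-pyrazol-5-yl on a carbonyl carbon gives an at least 6.2-fold higher number from compound 1 to compound 4 (0.79 log units; beyond the scatter) and shows that this position can hold a ring with a hydrogen-bond donor and a tert-butyl group without compound 4 sharing the short-lived limit of compound 1. The steps from compound 2 and from compound 3 to compound 4 cannot be read, as the upper end of the series remains a shared limit: (the limit of > 1 h in this assay, at which 3 of the 4 values shown sit).

On these data alone, how far compound 2, compound 3 and compound 4 each lie past that limit remains open. So does whether the pyrazole hydrogen or the tert-butyl group matters more, and whether an amine or a carboxylic acid on the ring would leave the half-life at this upper end.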